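The source may hold more compounds than are shown below. What is called first, only, known or untested is meant among the compounds shown, and "the series" means these compounds.

Of the compounds shown here, two sharing one core have so far been measured in an assay on isolated protein for binding affinity to leukotriene B4 receptor (Homo sapiens), tested at 0.1 uM; on this read-out lower numbers stand for less inhibition and higher numbers for more inhibition at the one concentration tested (going by the name of the read-out). Compound 1 `CCc1cc(C(C)=O)c(O)cc1OCCCC(C)(C)C#N` gives 13% in this assay, and compound 2 `CCc1cc(C(C)=O)c(O)cc1OCCCCC(C)(C)C#N` gives 5%. Among the measured compounds shown here, the single measured step between them, a number 8 percentage points lower from compound 1 to compound 2 (within the scatter), is the result of lengthening the saturated chain by one carbon. On the two numbers available, compound 2 stands lowest, with compound 1 as its nearest neighbour, and the gap between them lies within the scatter.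

Compound 3 `CCc1cc(C(C)=O)c(O)cc1OCCCCCC(C)(C)C#N` has not yet been measured. For the measured compounds named here, it differs from compound 2 by 2-cyano-2-methylpropyl in place of 1-cyano-1-methylethyl on a saturated chain carbon, four bonds along the chain from an oxygen on an aromatic ring, which is the same kind of chain lengthening as the one measured step, moved one bond further from the aromatic oxygen. Since that step stayed within the scatter, no step beyond the scatter is expected here either, and compound 3 is estimated to show no change at the digits printed from compound 2 to compound 3 (within the scatter). The expected inhibition of compound 3 in this assay is therefore 5%, within a range from -5% to 15%.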

Compound 3, a percentage reported as inhibition, at one concentration (the size of the read-out at that concentration, not a potency): 17%
Beside the measured number, compound 3's estimate is 12 percentage points below it; the whole stated range lies below it.
By their numbers in this assay, from the lowest: compounds 2, 1 and 3 (each within the scatter of the next, the first and the last beyond it).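

In this assay, the same kind of chain lengthening that stayed within the scatter one bond closer to the aromatic oxygen now gives a number 12 percentage points higher from compound 2 to compound 3 (beyond the scatter) in this series. Yet the comparison of the shortest and longest chains shown gives a number 4 percentage points higher from compound 1 to compound 3 (within the scatter), so these three compounds show no steady trend with chain length: only compound 2 and compound 3 lie beyond the scatter of each other, and compound 1 lies within the scatter of both. Nothing available explains this rise in the read-out.

A still longer chain ending in the same nitrile group would show whether the rise continues. On these data alone, it is also open whether a carboxylic acid or an amine at the chain end, in place of the nitrile, would change the read-out at this chain length.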